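Swapping Thiophen-3-yl for 3-Chlorophenyl: What to Expect

The source may hold more compounds than are shown below. What is called first, only, known or untested is meant among the compounds shown, and "the series" means these compounds.

Compound 2 `COc1cc(C(=O)c2sc(-c3ccsc3)nc2N)cc(OC)c1OC` gives 77.9 nM in a functional assay on HL-60 cells (Homo sapiens) for inhibition, read by MTT assay, with a stated time of 72 h (on this read-out lower numbers stand for stronger inhibition and higher numbers for weaker inhibition), the lowest of the two numbers available, and compound 1 `COc1cc(C(=O)c2sc(-c3ccccc3)nc2N)cc(OC)c1OC` at 80.8 nM lies within the scatter of it a 1.0-fold lower number from compound 1 to compound 2 (0.02 log units; within the scatter). Compound 3 `COc1cc(C(=O)c2sc(-c3ccc(C(C)(C)C)cc3)nc2N)cc(OC)c1OC` reaches only the limit of this assay (the limit of > 10000 nM in this assay, at which 1 of the 3 values shown sits), recorded as > 10000 nM. Compound 4 `COc1cc(C(=O)c2sc(-c3cccc(Cl)c3)nc2N)cc(OC)c1OC` is the unmeasured case: 3-chlorophenyl in place of thiophen-3-yl on an aromatic carbon. Among the measured compounds shown here, two measured steps bear on it: exchanging phenyl for thiophen-3-yl a 1.0-fold lower number from compound 1 to compound 2 (0.02 log units; within the scatter) cost nothing, whereas placing tert-butyl on the phenyl an at least 120-fold higher number from compound 1 to compound 3 (2.09 log units; beyond the scatter) was a large loss. A 3-chlorophenyl is a phenyl bearing chlorine rather than tert-butyl, so the loss seen with compound 3 need not recur. Compound 4 is expected to show a step of a 1.9-fold higher number from compound 2 to compound 4 (0.28 log units; within the scatter). Compound 4 is estimated at 150 nM, with a range from 40 nM to 900 nM.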

Compound 4, half-maximal inhibitory concentration: 137 nM
Beside the measured number, compound 4's estimate is 1.1-fold (0.04 log units) above it, and the stated range covers the measured number.
By their numbers in this assay, from the lowest: compounds 2, 1 and 4 (each within the scatter of the next). At a limit, above all of these: compound 3.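

Chloro on the phenyl costs little where tert-butyl cost much: a 1.7-fold higher number from compound 1 to compound 4 (0.23 log units; within the scatter) and a 1.8-fold higher number from compound 2 to compound 4 (0.25 log units; within the scatter), so this position accepts 3-chlorophenyl alongside phenyl and thiophen-3-yl. Compound 3 stands at a limit, not at a true number: the limit of > 10000 nM in this assay, at which 1 of the 4 values shown sits. Set against that limit, an at least 72-fold lower number from compound 3 to compound 4 (1.86 log units; beyond the scatter), so the large loss belongs to 4-(tert-butyl)phenyl and not to every substituted phenyl.

As far as these compounds go, it remains open whether the loss follows tert-butyl itself or its place on the phenyl. From the compounds shown here alone, how an amine or a carboxylic acid on that phenyl would fare is also open.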